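A few compounds are considered here, and "the series" means these few. Any claim that something is new, unique, unknown or untested is made for them only; others in the source may bear on it.

Measured compounds:
compound 1 `O=C(Nc1cccc(-n2cc(-c3ccncc3)c(-c3cc(O)cc(Cl)c3)n2)c1)Nc1ccc(Cl)c(C(F)(F)F)c1` — 34.6%
compound 2 `COc1cc(Cl)cc(-c2nn(-c3cccc(NC(=O)Nc4ccc(Cl)c(C(F)(F)F)c4)c3)cc2-c2ccncc2)c1` — 13.8%
compound 3 `COc1cc(Cl)cc(-c2nn(-c3cccc(NC(=O)Nc4cc(C(F)(F)F)cc(C(F)(F)F)c4)c3)cc2-c2ccncc2)c1` — 9.32%

All three were tested in a functional assay on SN12C cells (Homo sapiens) for inhibition, read by sulforhodamine B assay, with a stated time of 48 h, tested at 10 uM; on this read-out lower numbers stand for a stronger effect and higher numbers for a weaker effect at the one concentration tested. Compound 2 stands second highest of the three numbers: compound 3 lies slightly lower, within the scatter, so the two cannot be told apart, while compound 1 lies well higher, beyond the scatter. Among the measured compounds shown here, the only step between two compounds that differ in a single place is a number 20.8 percentage points lower from compound 1 to compound 2 (beyond the scatter), a methyl in place of hydrogen on an oxygen on an aromatic ring.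

Compound 4 `COc1cc(Cl)cc(-c2nn(-c3cccc(NC(=O)c4cccc(C(F)(F)F)c4)c3)cc2-c2ccncc2)c1` has not yet been measured. It differs from compound 2 in one place: 3-(trifluoromethyl)phenyl in place of (4-chloro-3-(trifluoromethyl)phenyl)amino on a carbonyl carbon. For the measured compounds named here, no measured step bears on a change of this kind, which removes a hydrogen-bond donor and a chlorine while keeping a trifluoromethyl group. Compounds 2 and 3 show that changing the substituents on that outer ring left the number within the scatter, but a change at the carbonyl carbon is of a different sort, and the measured steps give no guide to it. A weaker effect, meaning a higher number, is thought somewhat more likely than not, so the estimate for compound 4 in this assay is 30%, between 10% and 60%. This expected estimate corresponds to a step of a number 16.2 percentage points higher from compound 2 to compound 4 (beyond the scatter).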

Compound 4, a percentage reported as activity, at one concentration (the size of the read-out at that concentration, not a potency): 65.9%
Beside the measured number, compound 4's estimate is 35.9 percentage points below it, outside the stated range (above it).
By their numbers in this assay, from the lowest: compounds 3 and 2 (each within the scatter of the next); then compound 1; then compound 4.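

In this assay, among the compounds shown here, putting 3-(trifluoromethyl)phenyl in place of (4-chloro-3-(trifluoromethyl)phenyl)amino on a carbonyl carbon gives a number 52.1 percentage points higher from compound 2 to compound 4 (beyond the scatter), showing that the effect at this one concentration depends strongly on what sits at this position, which the earlier compounds had left untested. The change does more than one thing at once: the entering group keeps an aromatic ring of carbon and a trifluoromethyl group, but the hydrogen-bond donor and the chlorine both leave, so this single step cannot show which loss matters, or whether both do. Nothing measured here explains the weaker effect of compound 4.

Separating those two losses is the main open question: 4-chloro-3-(trifluoromethyl)phenyl placed directly on the carbonyl carbon would test the chlorine alone, while a methylene group in place of the amino nitrogen would test the donor with the ring kept. A methylamino link, which carries a methyl group on that nitrogen, would likewise show whether the amino hydrogen itself counts or whether the nitrogen alone is enough.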